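Cytotoxicity notes: from compound 2 to compound 3

The source may hold more compounds than are shown below. What is called first, only, known or untested is meant among the compounds shown, and "the series" means these compounds.

Compound 1 `CC(C)N(Cc1cccc(OCCCCCC(=O)O)c1)C(=O)c1ccc(-c2cccc3ccccc23)cc1` and compound 2 `CC(C)N(Cc1cccc(OCCCCCC(=O)O)c1)C(=O)c1ccc(-c2cccc(-c3ccccc3)c2)cc1` share one core and differ only in the aromatic group attached to it. In an ADME assay on HepG2 cells (Homo sapiens) for cytotoxicity, read by CellTiter-Glo and resazurin assay, with a stated time of 72 h (on this read-out lower numbers stand for an effect already at smaller amounts and higher numbers for an effect only at larger amounts of compound), compound 1 reaches only the limit of the assay, > 26000 nM. In this assay compound 2 likewise sits at the limit, > 26000 nM. The change 3-phenylphenyl in place of naphthalen-1-yl therefore gives a step that the two limits leave unreadable from compound 1 to compound 2, and the limit of > 26000 nM in this assay, at which 2 of the 2 values shown sit, is all the series holds for this read-out so far. Compound 3 `CC(=O)c1cccc(-c2ccc(C(=O)N(Cc3cccc(OCCCCCC(=O)O)c3)C(C)C)cc2)c1` is not yet measured; it differs from compound 2 by acetyl in place of phenyl on an aromatic carbon. Within the data shown here, no measured step bears directly on acetyl in place of phenyl. With both known values sitting at the limit, compound 3 is expected to remain there, amounting to an expected step that the limit leaves unreadable from compound 2 to compound 3 in this assay. Compound 3 is estimated at 40000 nM, within 15000 nM to 120000 nM, and will most probably again be reported only as a limit.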

Compound 3, half-maximal effective concentration: > 26000 nM
Compound 3: no number, only a limit; the forecaster's own chance of this, stated with the estimate: 85%; the middle value lies beyond the limit too.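

In this assay, among these compounds, compound 3 gives only a limit, > 26000 nM, so no step among compound 1, compound 2 and compound 3 can be read: the limit of > 26000 nM in this assay, at which 3 of the 3 values shown sit.

The compounds shown leave open whether any aromatic group on the shared core brings a readable value in this assay, and how far these three compounds truly differ.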